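Methyl for Fluoro on a Weak Receptor Agonist

This account rests on a few compounds, and the source may have more. Where it says the series, first, only, none or still open, it means among the compounds named here.

Going by the values given here, compound 2 `Cc1ccc(Nc2nc(N)nc(COc3cc(N4CCCC4=O)ccc3F)n2)cc1Cl` gives 33100 nM in an assay on COS-7 cells for agonist activity at Free fatty acid receptor 1 (Homo sapiens), read by scintillation counting and inositol phosphate accumulation, with a stated time of 90 min (on this read-out lower numbers stand for an effect already at smaller amounts and higher numbers for an effect only at larger amounts of compound), the higher of the two numbers known here, while compound 1 `Cc1cc(=O)oc2cc(OCc3nc(N)nc(Nc4ccc(C(C)C)cc4)n3)ccc12` gives 460 nM in this assay, a gap beyond the usual scatter. Compound 3 `Cc1ccc(Nc2nc(N)nc(COc3cc(N4CCCC4=O)ccc3C)n2)cc1Cl` differs from compound 2 by methyl in place of fluoro on an aromatic carbon. Among the compounds with values here, no measured pair shows this change, so its direction is open; a step within the scatter, or only just beyond it, in either direction is expected. Compound 3 is expected to give 20000 nM, between 5000 nM and 80000 nM, meaning an expected step of a 1.7-fold lower number from compound 2 to compound 3 (0.22 log units; within the scatter).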

Compound 3, half-maximal effective concentration: 7450 nM
The estimate for compound 3 lay 2.7-fold (0.43 log units) above the measured number; the range from low to high includes it.
By their numbers in this assay, from the lowest: compound 1; then compound 3; then compound 2.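

At this aromatic carbon, ortho to a large group and para to a 2-oxopyrrolidin-1-yl group, the position proves sensitive to the exchange of one heavy atom: in this assay there is a 4.4-fold lower number from compound 2 to compound 3 (0.65 log units; beyond the scatter), a modest step but one beyond the scatter. This gives the first measured direction for methyl in place of fluoro in this series. No available evidence explains the step.

As far as these compounds go, whether an amine, a carboxylic acid or a longer chain at this carbon would lower the number further remains open. So does whether methyl in place of fluoro would move the same way on another core.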